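Dropping a Methyl from a Nitro-Bearing Ring Nitrogen

This account rests on a few compounds, and the source may have more. Where it says the series, first, only, none or still open, it means among the compounds named here.

Compound 1 `COc1cc(/C=C/c2nnc(-c3cc([N+](=O)[O-])cn3C)o2)ccc1O` was tested in an ADME assay on Vero cells (Chlorocebus sabaeus) for cytotoxicity, read by MTT assay, with a stated time of 72 h (a higher number here means a weaker inhibitor, a lower number a stronger inhibitor), where compound 1 gives 203000 nM. Among the compounds with values here, only one other value exists: compound 2 `O=[N+]([O-])c1c[nH]c(-c2nnc(-c3cc4cc(Cl)ccc4[nH]3)o2)c1` gives 329000 nM, and the two numbers lie within the usual scatter of each other, so neither stands apart. Compound 3 `COc1cc(/C=C/c2nnc(-c3cc([N+](=O)[O-])c[nH]3)o2)ccc1O` differs from compound 1 in a single place: hydrogen in place of methyl on an aromatic nitrogen. Within the data shown here, no measured pair shows this exact change, so no step beyond the scatter is expected, and compound 2, which also carries a hydrogen on its ring nitrogen, sits close to compound 1. For compound 3 the estimate is 230000 nM, ranging from 100000 nM to 500000 nM, an expected step of a 1.1-fold higher number from compound 1 to compound 3 (0.05 log units; within the scatter).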

Compound 3, half-maximal inhibitory concentration: 221000 nM
For compound 3 the middle estimate is 1.0-fold (0.02 log units) above the measured one; low and high end bracket the measured number.
By their numbers in this assay, from the lowest: compounds 1, 3 and 2 (each within the scatter of the next).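

Within the data shown here, compound 3 differs from compound 1 in one place only, so this pair gives the first direct reading of this position: in this assay, hydrogen in place of methyl on an aromatic nitrogen amounts to a 1.1-fold higher number from compound 1 to compound 3 (0.04 log units; within the scatter) and no more. At this nitrogen, methyl and hydrogen cannot be told apart in this measurement. No evidence at hand speaks to the reason for this result. Still open, going by these compounds, is whether a longer chain or a benzyl group on the same nitrogen would read the same way. Also open, on these data alone, is what a nitrile in place of the nitro group would give.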